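This account rests on a few compounds, and the source may have more. Where it says the series, first, only, none or still open, it means among the compounds named here.

In a functional assay on C6 cells (Rattus norvegicus) for inhibition, read by sulforhodamine B assay, with a stated time of 72 h (a lower number here means that less compound is needed, a higher number that more compound is needed for the effect), compound 3 `CC(C)(C)c1ccc(C(=O)/C=C/c2ccco2)cc1` gives 18500 nM. Compound 1 `CC(C)(C)c1ccc(C(=O)/C=C/c2ccc([N+](=O)[O-])o2)cc1` gives 28600 nM, and the step of a 1.5-fold lower number from compound 1 to compound 3 (0.19 log units; within the scatter) keeps the two level. Compound 2 `CCCCc1ccc(C(=O)/C=C/c2ccc([N+](=O)[O-])o2)cc1`, at 1700 nM, has a clearly lower number than either. Compound 4 `CCCCc1ccc(C(=O)/C=C/c2ccco2)cc1` has not yet been measured. It differs from compound 3 by one change, butyl in place of tert-butyl on an aromatic carbon.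

The same swap appears once among the measured compounds, in the step of a 17-fold lower number from compound 1 to compound 2 (1.23 log units; beyond the scatter), which is large. That pair carries a nitro group, whereas compound 3 and compound 4 carry hydrogen at that place. The step of a 1.5-fold lower number from compound 1 to compound 3 (0.19 log units; within the scatter) shows no real difference from that exchange when tert-butyl is present, so the swap may well carry over. One pair is thin evidence, however, and the size may not repeat exactly.

A large fall in the number is therefore expected, an estimated 7.4-fold lower number from compound 3 to compound 4 (0.87 log units; beyond the scatter). Compound 4 is expected at about 2500 nM, with an estimated range from 800 nM to 9000 nM.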

Compound 4, half-maximal effective concentration: 8400 nM
Estimate against measurement, compound 4: 3.4-fold (0.53 log units) below; the measured number falls inside the stated range.
By their numbers in this assay, from the lowest: compound 2; then compound 4; then compounds 3 and 1 (each within the scatter of the next).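

In this assay butyl in place of tert-butyl still lowers the number on the core without the nitro group, so the direction of this change on the aromatic carbon holds on both cores, but its size does not: the same change on two cores in this assay, a 17-fold lower number (1.23 log units; beyond the scatter) from compound 1 to compound 2 and a 2.2-fold lower number (0.34 log units; beyond the scatter) from compound 3 to compound 4, 7.6-fold (0.88 log units) apart, beyond the scatter of two such steps. Hydrogen in place of nitro made no real difference with tert-butyl present, yet with butyl present it gives a 4.9-fold higher number from compound 2 to compound 4 (0.69 log units; beyond the scatter) and the butyl swap alone gives a 2.2-fold lower number from compound 3 to compound 4 (0.34 log units; beyond the scatter). The two places therefore do not add up independently, and the gain from butyl is largest when the nitro group is present: the same change on two cores in this assay, a 1.5-fold lower number (0.19 log units; within the scatter) from compound 1 to compound 3 and a 4.9-fold higher number (0.69 log units; beyond the scatter) from compound 2 to compound 4, 7.6-fold (0.88 log units) apart, beyond the scatter of two such steps.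

Going by these compounds, whether this link between the two places extends to other groups, such as propyl, a longer chain like hexyl, or an amine, stays open. The four compounds show that the link exists, but they cannot tell why.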